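A few compounds are considered here, and "the series" means these few. Any claim that something is new, unique, unknown or untested is made for them only; others in the source may bear on it.

Compound 1, `CC(C)[C@H](NC(=O)COc1cccc2ccccc12)C(=O)N[C@@H](CC(=O)O)C(=O)COc1ccc(C#N)cc1`: in a functional assay on Jurkat cells (Homo sapiens) (a higher number here means a weaker inhibitor, a lower number a stronger inhibitor), compound 1 gives > 100000 nM, which is a limit of the assay and not a number.
Compound 2, `CC(C)[C@H](NC(=O)COc1cccc2ccccc12)C(=O)N[C@@H](CC(=O)O)C(=O)COc1ccc(F)cc1`: in this assay compound 2 gives > 100000 nM, again a limit of the assay.

Within the data shown here, compound 1 therefore stands only at a limit, and the one further value shown is a limit as well; both sit at the limit of > 100000 nM in this assay, at which 2 of the 2 values shown sit. Compound 3, `CC(C)[C@H](NC(=O)COc1cccc2ccccc12)C(=O)N[C@@H](CC(=O)O)C(=O)COc1ccc(F)c(F)c1F`, differs from compound 1 by 2,3,4-trifluorophenyl in place of 4-cyanophenyl on an oxygen on a saturated carbon. Among the measured compounds shown here, the only measured step, a step that the two limits leave unreadable from compound 1 to compound 2, is left unreadable by the two limits, so it gives neither a size nor a direction to carry over to this change, and no step beyond the scatter can be foreseen in either direction. Compound 3 is estimated to give 150000 nM in this assay, with a range from 30000 nM to 1000000 nM, and the most likely outcome is once more a limit rather than a number. The expected step is a step that the limit leaves unreadable from compound 1 to compound 3.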

Compound 3, half-maximal inhibitory concentration: 35800 nM
Compound 3: middle estimate off by 4.2-fold (0.62 log units), on the high side; the measured number falls inside the stated range.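

In this assay, among these compounds, this position, the aryl group on the oxygen on a saturated carbon, turns out to bear on the number: 2,3,4-trifluorophenyl in place of 4-cyanophenyl gives an at least 2.7-fold lower number from compound 1 to compound 3 (0.44 log units; beyond the scatter) and in place of 4-fluorophenyl gives an at least 2.7-fold lower number from compound 2 to compound 3 (0.44 log units; beyond the scatter) and so brings the series off the limit for the first time. The step between the two earlier compounds cannot be read, so they alone gave no sign that a change here could matter. Among the compounds shown here, compound 3 now supplies the only number in the set, and with it a reference for further changes at this place.

From the compounds shown here alone, what a plain phenyl or a pentafluorophenyl on this oxygen would give stays open. The full size of both steps also stays open, because each starts from a compound that stands at a limit: the limit of > 100000 nM in this assay, at which 2 of the 3 values shown sit.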